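Spiro-oxindole triazole series: notes on antiproliferative activity

The compounds below may be only part of what the source reports. "The series", "measured", "known", "first", "only" and "open" are said of these compounds alone.

Measured compounds:
- Compound 1 `Cc1ccc(-n2nncc2CN2C(=O)C3(C(C#N)=C(N)Oc4c3c3nc5ccccc5nc3c3ccccc43)c3ccccc32)c(C)c1` gives > 50000 nM in a functional assay on HepG2 cells (Homo sapiens) for antiproliferative activity, read by MTT assay, with a stated time of 48 h (a lower number here means a stronger inhibitor, a higher number a weaker inhibitor), a limit of the assay.
- Compound 2 `N#CC1=C(N)Oc2c(c3nc4ccccc4nc3c3ccccc23)C12C(=O)N(Cc1cnnn1-c1cc(Cl)ccc1Cl)c1ccccc12` gives > 50000 nM in this assay, a limit.
- Compound 3 `Cc1ccccc1-n1nncc1CN1C(=O)C2(C(C#N)=C(N)Oc3c(N)cc4nc5ccccc5nc4c32)c2ccccc21` gives > 50000 nM in this assay, a limit.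

Compound 3 stands at the assay limit, and it is not separated from compounds 1 and 2 because of the limit of > 50000 nM in this assay, at which 3 of the 3 values shown sit. Among the measured compounds shown here, the only measured step, a step that the two limits leave unreadable from compound 1 to compound 2, is a swap of the aryl group on the same aromatic nitrogen, and its size is not readable. Compound 4 `N#CC1=C(N)Oc2c(N)cc3nc4ccccc4nc3c2C12C(=O)N(Cc1cnnn1-c1cccc(C(F)(F)F)c1)c1ccccc12` differs from compound 3 by 3-(trifluoromethyl)phenyl in place of 2-methylphenyl on an aromatic nitrogen. For the measured compounds named here, no measured step gives a readable size for a change of this kind, so no step beyond the scatter is expected in this assay. Compound 4 is therefore expected to sit at the same limit, a step that the limit leaves unreadable from compound 3 to compound 4. The estimate for compound 4 is 70000 nM, in the range 20000 nM to 250000 nM.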

Compound 4, half-maximal inhibitory concentration: 15800 nM
The estimate for compound 4 lay 4.4-fold (0.65 log units) above the measured number; measured number outside the range, below it.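

In this assay, 3-(trifluoromethyl)phenyl in place of 2-methylphenyl on the aromatic nitrogen gives an at least 3.1-fold lower number from compound 3 to compound 4 (0.50 log units; beyond the scatter). Among the compounds shown here, this is the first readable step at this position, where the swap between compound 1 and compound 2 could not be read, so the aryl group here can move the number off the limit. Only a bound on the size can be given, since compound 3 is itself a limit: the limit of > 50000 nM in this assay, at which 3 of the 4 values shown sit.

Open, as far as these compounds go, is whether 3-methylphenyl or 2-(trifluoromethyl)phenyl on this nitrogen would give a similar step. Also open, from the compounds shown here alone, is whether 3-(trifluoromethyl)phenyl would give a readable number on the core of compound 1.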